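Bicyclic pyrazole replacements and microsomal clearance

The compounds below may be only part of what the source reports. "The series", "measured", "known", "first", "only" and "open" are said of these compounds alone.

Compound 1: `CC(=O)N[C@@H]1CCC[C@H](C(=O)Nc2cc(-c3cnn(C)c3C)c(Cl)cn2)C1` — 3.3 mL.min-1.g-1
Compound 2: `CC(=O)N[C@@H]1CCC[C@H](C(=O)Nc2cc(-c3cnn4c3COCC4)c(Cl)cn2)C1` — < 3 mL.min-1.g-1
Compound 3: `CC(=O)N[C@@H]1CCC[C@H](C(=O)Nc2cc(-c3cnn4c3NCCC4)c(Cl)cn2)C1` — not yet measured

Among the measured compounds shown here, compound 1 stands with the only full number in an ADME assay on microsomes from liver (Homo sapiens) for metabolic stability; on this read-out lower numbers stand for slow clearance and higher numbers for fast clearance; in this assay compound 1 gives 3.3 mL.min-1.g-1. For compound 2 this assay reports only a limit, < 3 mL.min-1.g-1, so its exact number is not known. The step of an at least 1.1-fold lower number from compound 1 to compound 2 (0.04 log units; that floor lies within the scatter) is set by that floor, (the limit of < 3 mL.min-1.g-1 in this assay, at which 1 of the 2 values shown sits), and stays within the usual scatter.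

Compound 3 differs from compound 1 in that (a group of 9 heavy atoms (6 carbon, 3 nitrogen; one five-membered aromatic ring with 2 hetero atoms, one six-membered non-aromatic ring with 2 hetero atoms) in place of a group of 7 heavy atoms (5 carbon, 2 nitrogen; one five-membered aromatic ring with 2 hetero atoms), on an aromatic carbon). For the measured compounds named here, the only step that bears on this change is the one from compound 1 to compound 2, where a different fused six-membered ring entered at the same place and the number did not move beyond the scatter. The same kind of change here is therefore expected to give no step beyond the scatter, or at most a small one downward. Compound 3 is expected to show 3 mL.min-1.g-1, between 1.5 mL.min-1.g-1 and 6.5 mL.min-1.g-1, a step of a 1.1-fold lower number from compound 1 to compound 3 (0.04 log units; within the scatter).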

Compound 3, intrinsic clearance in microsomes: 6.2 mL.min-1.g-1
Estimate against measurement, compound 3: 2.1-fold (0.32 log units) below, within the range that was stated.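

In this assay, this aromatic carbon now separates two fused six-membered rings of the same heavy-atom count: exchanging the oxygen-containing ring for the one with a third nitrogen gives an at least 2.0-fold higher number from compound 2 to compound 3 (0.31 log units; beyond the scatter). Among the compounds shown here, this is the first step beyond the scatter, so the atoms of the fused ring can matter at this position, whereas replacing the 1,5-dimethyl-1H-pyrazol-4-yl group gives a 1.9-fold higher number from compound 1 to compound 3 (0.27 log units; within the scatter), which stays within it. The true size of the step between the two fused rings is not known, as the value for compound 2 is a limit: the limit of < 3 mL.min-1.g-1 in this assay, at which 1 of the 3 values shown sits.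

The compounds shown leave open whether a methyl group on the added ring nitrogen, or a plain methylene in its place, would give a number nearer to that of compound 3 or to the limit of compound 2. They also leave open how a five- or seven-membered fused ring would read at this position.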